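The compounds below may be only part of what the source reports. "The series", "measured", "known", "first", "only" and "open" are said of these compounds alone.

Working notes on the series. Three compounds have numbers in a functional assay on the whole organism (Tail, strain ICR) with Mus musculus as the target, in the tail flick test, with a stated time of 120 min, at a dose of 25 umol/kg by the oral route (on this read-out higher numbers stand for a stronger effect at the one dose given and lower numbers for a weaker effect), so far. Compound 1, `O=C(O)[C@@H]1CCCN1C(=O)CN(c1nc(Cl)nc2[nH]cnc12)C1CC1`, gives 23.6%. Compound 2, `NCCCC[C@H](NC(=O)CN(c1nc(Cl)nc2[nH]cnc12)C1CC1)C(=O)OCc1ccccc1`, gives 16.8%. Compound 3, `C[C@H](NC(=O)CN(c1ncnc2c1ncn2C1CCCCO1)C1CC1)C(=O)OCc1ccccc1`, gives 25.3%. On these numbers compound 2 sits at the lower end of the three, but its gaps to compound 1 and to compound 3 both lie within the usual scatter, so nothing separates the three beyond repeat-measurement noise.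

The next compound in line is compound 4, `CC(C)[C@H](NC(=O)CN(c1nc(Cl)nc2[nH]cnc12)C1CC1)C(=O)OCc1ccccc1`. Relative to compound 2 the change is isopropyl in place of 4-aminobutyl on a saturated chain carbon bound to an amide-type nitrogen and a carbonyl carbon. For the measured compounds named here, no pair of measured compounds that differ in just one place is available, so the step has no direct precedent; compound 3 carries a different core and a different substituent on the same chain carbon and cannot be read as a model for it.

Given that every number so far falls inside one scatter band, the step is expected to be small, with no direction beyond the scatter: the expected step is a number 5.2 percentage points higher from compound 2 to compound 4 (within the scatter). For compound 4 in this assay the estimate is 22%, in the range 10% to 35%.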

Compound 4, a percentage reported as activity, at one dose (the size of the read-out at that dose, not a potency): 27.3%
The estimate for compound 4 lay 5.3 percentage points below the measured number, and the stated range covers the measured number.
By their numbers in this assay, from the lowest: compounds 2, 1, 3 and 4 (each within the scatter of the next, the first and the last beyond it).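

For the compounds shown here, replacing 4-aminobutyl with isopropyl on a saturated chain carbon bound to an amide-type nitrogen and a carbonyl carbon gives, in this assay, a number 10.5 percentage points higher from compound 2 to compound 4 (beyond the scatter), the only step so far and a modest one. This position therefore has a readable effect on the result at the one dose given. With the shared core and the benzyl ester unchanged, the terminal amine and longer chain of compound 2 are not needed for this level of effect, and no measurement bears on why the step occurs.

This single step does not separate removal of the amine from shortening of the chain. A plain butyl chain at this position would separate the two, while a carboxylic acid at the chain end would show whether another terminal group is tolerated.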